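The source may hold more compounds than are shown below. What is called first, only, known or untested is meant among the compounds shown, and "the series" means these compounds.

Measured so far in a functional assay on CCRF-CEM cells (Homo sapiens), read by MTT assay, with a stated time of 72 h; a lower number here means a stronger inhibitor, a higher number a weaker inhibitor:
compound 1 `Nc1nc(N)c2c(-c3ccsc3)cn([C@@H]3O[C@H](CO)[C@@H](O)[C@H]3O)c2n1`: compound 1 gives > 20000 nM, a limit of the assay rather than a number.
compound 2 `COc1ncnc2c1c(-c1ccsc1)cn2[C@@H]1O[C@H](CO)[C@@H](O)[C@H]1O`: compound 2 gives 2570 nM.
compound 3 `C#Cc1cn([C@@H]2O[C@H](CO)[C@@H](O)[C@H]2O)c2nc(N)nc(OC)c12`: compound 3 gives > 100000 nM, again a limit and not a number.

Compound 3 therefore stands at the weak end of what is shown: its value is the limit of > 100000 nM in this assay, at which 1 of the 3 values shown sits. Compound 1 also sits at a limit, (the limit of > 20000 nM in this assay, at which 1 of the 3 values shown sits). For the measured compounds named here, only compound 2 carries a true number in this assay, and it is the one compound with thiophen-3-yl and a readable result.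

The step from compound 3 to compound 4 `COc1nc(N)nc2c1c(-c1ccsc1)cn2[C@@H]1O[C@H](CO)[C@@H](O)[C@H]1O` is thiophen-3-yl in place of ethynyl on an aromatic carbon. Going by the values given here, no measured pair shows this same change, so its size can only be expected, not read off. The two compounds that carry thiophen-3-yl give one number and one limit, while compound 3 with ethynyl gives only a limit, so the step from compound 3 to compound 4 is expected to bring a gain in potency in this assay, estimated as an at least 8.3-fold lower number from compound 3 to compound 4 (0.92 log units; beyond the scatter), with the real chance that compound 4 still comes back as a limit. Compound 4 is estimated at 12000 nM, with a range from 2500 nM to 60000 nM.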

Compound 4, half-maximal inhibitory concentration: > 20000 nM
Compound 4 gave a limit, no number; the forecaster's own chance of this, stated with the estimate: 35%; middle value at least 1.6-fold (0.22 log units) away from the limit.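

In this assay compound 4 joins compound 1 at the same limit, which is a limit of the assay and not a number: the limit of > 20000 nM in this assay, at which 2 of the 4 values shown sit.

Thiophen-3-yl on this aromatic carbon is therefore not enough for a readable result, as compound 2 is the only one of the three thiophen-3-yl compounds with a number, and amino in place of hydrogen on an aromatic carbon, with thiophen-3-yl and methoxy kept, gives an at least 7.7-fold higher number from compound 2 to compound 4 (0.89 log units; beyond the scatter). The exchange of ethynyl for thiophen-3-yl still has no measured size, and neither does methoxy in place of amino: both steps have a limit at each end and cannot be read.

The compounds shown do not tell how ethynyl behaves on the core of compound 2, the only core here that gives a number. They also leave open whether a phenyl or a furan-3-yl group on this aromatic carbon, or a methylamino group in place of the amino group of compound 4, would bring the series back to a readable number.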